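The compounds below may be only part of what the source reports. "The series", "measured", "known", "first", "only" and "open" are said of these compounds alone.

Measured in a functional assay on K562 cells (Homo sapiens) for inhibition, read by trypan blue exclusion, with a stated time of 72 h; on this read-out higher numbers stand for weaker inhibition and lower numbers for stronger inhibition:

- compound 1 `Cn1c(=O)c(S(=O)(=O)c2ccc(F)cc2)cc2cnc(Nc3ccc4occc4c3)nc21`: 5000 nM
- compound 2 `CN1CCN(c2ccc(Nc3ncc4cc(S(=O)(=O)c5ccc(F)cc5F)c(=O)n(C)c4n3)cc2)CC1`: 5000 nM
- compound 3 `Cn1c(=O)c(S(=O)(=O)c2ccc(F)cc2F)cc2cnc(Nc3ccc4occc4c3)nc21`: 15000 nM

Compound 3 has the highest number of the three in this assay, and it lies beyond the scatter from both compound 1 and compound 2. The next compound, compound 4 `Cn1c(=O)c(S(=O)(=O)c2ccc(F)cc2F)cc2cnc(Nc3ccccn3)nc21`, keeps everything in compound 3 except one group: pyridin-2-yl in place of 1-benzofuran-5-yl on a nitrogen on an aromatic ring. In words, pyridin-2-yl stands in place of 1-benzofuran-5-yl on a nitrogen on an aromatic ring.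

Among the compounds with values here, only one step has been measured between compounds that differ in one place, a 3.0-fold higher number from compound 1 to compound 3 (0.48 log units; beyond the scatter). It is modest, and it concerns a fluoro in place of hydrogen on an aromatic carbon, not the group that changes here. Within the data shown here, no measured step covers this exchange directly. The only other hint comes from compound 2, which has a different group on that nitrogen and gives 5000 nM, while compound 3 gives 15000 nM. That shows the number can move with this group, but not which way it will go for pyridin-2-yl.

With no firm direction, the expected change is small, and no step beyond the scatter is expected: a 1.5-fold lower number from compound 3 to compound 4 (0.18 log units; within the scatter). Compound 4 is estimated at 10000 nM, with an expected range of 3500 nM to 30000 nM.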

Compound 4, half-maximal inhibitory concentration: 35000 nM
The estimate for compound 4 lay 3.5-fold (0.54 log units) below the measured number, and the stated range ends below it.
By their numbers in this assay, from the lowest: compounds 1 and 2 (each within the scatter of the next); then compound 3; then compound 4.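

In this assay, within the data shown here, the exchange on this nitrogen gives a 2.3-fold higher number from compound 3 to compound 4 (0.37 log units; beyond the scatter), the first measured step at this place on the molecule, and it runs towards weaker inhibition. The earlier compounds shown here showed only that a fluoro on an aromatic carbon could move the number, whereas this result shows that the group on the nitrogen matters too, even in a compound that already had the highest number of the first three. The exchange replaces a group of two fused aromatic rings with a single six-membered aromatic ring that holds a nitrogen, but nothing available explains why the number rises.

Among these compounds, the single step cannot separate the loss of the five-membered ring from the entry of the ring nitrogen, and a plain phenyl on the same nitrogen would bear directly on that question. As far as these compounds go, it also remains open whether a pyridin-2-yl carrying an amine such as morpholine would behave like pyridin-2-yl itself, and whether the same exchange would have a similar effect in a compound with a single fluoro on its aromatic ring.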